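The source may hold more compounds than are shown below. What is called first, only, known or untested is meant among the compounds shown, and "the series" means these compounds.

Measured so far:
Compound 1, `O=[N+]([O-])c1ccccc1/C=N/N=C(\S)Nc1ncc(C2CCC2)o1` — "not determined" (no result reported) in a functional assay on Vero cells (Chlorocebus sabaeus) for cytotoxicity; a higher number here means a weaker inhibitor, a lower number a stronger inhibitor.
Compound 2, `C/C(=N\N=C(/S)Nc1ncc(C2CCC2)o1)c1ccc([N+](=O)[O-])cc1` — 62.5 ug/mL in this assay.
Compound 3, `S=C(NN=C(c1ccccc1)c1ccccc1)Nc1ncc(C2CCC2)o1` — > 62.5 ug/mL in this assay.

Compound 3 stands at the limit of > 62.5 ug/mL in this assay, at which 1 of the 3 values shown sits; that figure is a limit of the assay and not a number. Compound 1 contributes no value at all, so compound 2 is the only entry with a single number.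

Compound 4, `S=C(N/N=C(\c1ccccc1)c1ccc(Br)cc1)Nc1ncc(C2CCC2)o1`, differs from compound 3 by bromo in place of hydrogen on an aromatic carbon. Among the compounds with values here, no step between measured compounds exists to guide the change, so the expected step from compound 3 to compound 4 is estimated as none beyond the usual scatter, a number no higher from compound 3 to compound 4 (the limit leaves the size open). Compound 4 is therefore expected to give about 62.5 ug/mL, within an estimated range from 35 ug/mL to 110 ug/mL, and most likely only a limit will again be reported.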

Compound 4, half-maximal inhibitory concentration: > 62.5 ug/mL
Compound 4: a limit, no number; the forecaster's own chance of this, stated with the estimate: 70%; the middle value lies on the limit itself.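

No step from compound 3 to compound 4 can be read, because both results are limits of the assay and not numbers: the limit of > 62.5 ug/mL in this assay, at which 2 of the 4 values shown sit.

The compounds shown leave open whether bromo in place of hydrogen changes the result in this assay at all.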